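The source may report more compounds than this note shows. Statements on the series, on what has been measured and on what is new or still open speak of the compounds shown alone.

Compound 1 `COc1cc(C#N)ccc1OCc1nnc(-c2ccccc2)o1` gives 32200 nM in a functional assay on MCF7 cells (Homo sapiens) for cytotoxicity, read by MTT assay, with a stated time of 48 h; a lower number here means a stronger inhibitor, a higher number a weaker inhibitor.
Compound 2 `COc1ccc(-c2nnc(COc3ccc(C#N)cc3OC)o2)cc1` gives 11100 nM in this assay.
Compound 3 `c1ccc(-c2nnc(COc3ccc(-c4nnco4)cc3)o2)cc1` reaches only the limit of this assay, > 50000 nM.

The change from compound 1 to compound 2 is methoxy in place of hydrogen on an aromatic carbon, and it brought a 2.9-fold lower number from compound 1 to compound 2 (0.46 log units; beyond the scatter). Compound 4 `COc1ccc(-c2nnc(COc3ccc(-c4nnco4)cc3)o2)cc1` carries the same change on the core of compound 3: methoxy in place of hydrogen on an aromatic carbon. How the core of compound 3 differs from that of compound 1 is not broken down here. Compound 3 sits at the limit of > 50000 nM in this assay, at which 1 of the 3 values shown sits, so the starting point of the new step is not a number. For compound 4 a step about like the earlier one is expected, an at least 1.2-fold lower number from compound 3 to compound 4 (0.09 log units; that floor lies within the scatter), resting on the step from compound 1 to compound 2 a 2.9-fold lower number from compound 1 to compound 2 (0.46 log units; beyond the scatter). Compound 4 is therefore estimated at 40000 nM, between 15000 nM and 100000 nM.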

Compound 4, half-maximal inhibitory concentration: 31200 nM
Compound 4: middle estimate off by 1.3-fold (0.11 log units), on the high side; measured number inside the range.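

On the core of compound 3, the change from phenyl to 4-methoxyphenyl gives an at least 1.6-fold lower number from compound 3 to compound 4 (0.20 log units; that floor lies within the scatter) in this assay. From the compounds shown here alone, compound 3 stands at > 50000 nM, which is a limit and not a number, so the new step has only a floor and its true size stays unknown. The step points the same way as on the core of compound 1, but this does not show that the change carries over with the same size: the same change on two cores in this assay, a 2.9-fold lower number (0.46 log units; beyond the scatter) from compound 1 to compound 2 and an at least 1.6-fold lower number (0.20 log units; that floor lies within the scatter) from compound 3 to compound 4; the limit leaves it open whether they differ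

The compounds shown leave open what other groups at this place, such as an amine or a carboxylic acid, would do to the number. They also leave open whether the methoxy step would appear on further cores.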